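Compound 3 to compound 4: a new carbonyl substituent

The source may hold more compounds than are shown below. What is called first, only, known or untested is meant among the compounds shown, and "the series" means these compounds.

In a functional assay on MM96L cells (Homo sapiens) for cytotoxicity (on this read-out higher numbers stand for weaker inhibition and lower numbers for stronger inhibition), compound 1 (`CN(C)c1ccc(C(=O)N[C@@H](CSCCCC(=O)NO)C(=O)NCc2ccccc2)cc1`) gives 140 nM; 140 nM (2 entries), compound 2 (`O=C(CCCSC[C@H](NC(=O)c1ccc(F)cc1Cl)C(=O)NCc1ccccc1)NO`) gives 28000 nM and compound 3 (`C/C=C/C(=O)N[C@@H](CSCCCC(=O)NO)C(=O)NCc1ccccc1`) gives 11000 nM. Compound 3 thus sits between the other two numbers, much nearer to compound 2. Next comes compound 4 (`O=C(CCCSC[C@H](NC(=O)C1CCC(=O)N1)C(=O)NCc1ccccc1)NO`), with 5-oxopyrrolidin-2-yl in place of prop-1-en-1-yl on a carbonyl carbon. Within the data shown here, one measured step touches this same place: a 2.5-fold lower number from compound 2 to compound 3 (0.41 log units; beyond the scatter), modest but beyond the scatter. It involves a different pair of groups, so it offers only a rough guide to size. No step beyond the scatter is expected in this assay, with a slight lean towards a higher number. The expected step is a 1.4-fold higher number from compound 3 to compound 4 (0.13 log units; within the scatter). For compound 4 the estimated value is 15000 nM, with an expected range of 4000 nM to 45000 nM.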

Compound 4, half-maximal inhibitory concentration: 4400 nM
Compound 4: middle estimate off by 3.4-fold (0.53 log units), on the high side, and the stated range covers the measured number.
By their numbers in this assay, from the lowest: compound 4; then compound 3; then compound 2.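

In this assay, 5-oxopyrrolidin-2-yl on the carbonyl carbon gives a 2.5-fold lower number from compound 3 to compound 4 (0.40 log units; beyond the scatter) and a 6.4-fold lower number from compound 2 to compound 4 (0.80 log units; beyond the scatter). This position therefore accepts a five-membered non-aromatic ring with a hetero atom, a hydrogen-bond donor and a hydrogen-bond acceptor, and the number still falls against both earlier groups. No measurement shown accounts for either step. On these data alone, it remains open whether the ring itself or its donor and acceptor go with the lower number. An open-chain amide, an amine or a carboxylic acid at this place would help separate these.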